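The compounds below may be only part of what the source reports. "The series", "measured", "known", "first", "only" and "open" are said of these compounds alone.

Measured so far:
- compound 1 `N#CCC1=NN=C(c2ccc(Br)cc2)C(Br)O1` gives 70700 nM
- compound 2 `N#CCC1=C(C#N)CC(c2ccc([N+](=O)[O-])cc2)=C(CC(=O)c2ccc([N+](=O)[O-])cc2)O1` gives 30 nM
- compound 3 `N#CCC1=NN=C(c2ccc(Br)cc2)C(CC(=O)c2ccc(Br)cc2)O1` gives 30400 nM

In a functional assay on MCF7 cells (Homo sapiens) for inhibition, read by sulforhodamine B assay, with a stated time of 48 h (on this read-out lower numbers stand for stronger inhibition of growth and higher numbers for weaker inhibition of growth), compound 1 has the highest number of the three. Compound 3 sits nearest, with a lower number that lies beyond the scatter, and compound 2 lies furthest, far lower. Compound 2 is built on a different core, so its value says nothing direct about the core of compound 1. Compound 3 shares that core with compound 1 and differs at the saturated ring carbon, where it carries a larger group; its lower number shows that this carbon tolerates change without the value moving greatly.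

Compound 4 `N#CCC1=NN=C(c2ccc(Br)cc2)CO1` is the next member: hydrogen in place of bromo on a saturated ring carbon. Among the measured compounds shown here, no measured pair shows this exact change. For the measured compounds named here, the group leaving is small, and the only comparison at this carbon (compound 1 against compound 3) shows a modest move. The expected step in this assay is therefore small, with no clear direction, likely within the scatter.

Compound 4 is expected to give 80000 nM, within 25000 nM to 250000 nM, which corresponds to an estimated step of a 1.1-fold higher number from compound 1 to compound 4 (0.05 log units; within the scatter).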

Compound 4, concentration for 50% growth inhibition: 1500 nM
Compound 4: the middle estimate sits 53-fold (1.73 log units) above what was measured; the whole stated range lies above it.
By their numbers in this assay, from the lowest: compound 2; then compound 4; then compound 3; then compound 1.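

In this assay, among the compounds shown here, the saturated ring carbon next to the ring oxygen proves far more sensitive than the earlier compounds indicated: hydrogen in place of bromo gives a 47-fold lower number from compound 1 to compound 4 (1.67 log units; beyond the scatter). Compound 3 at 30400 nM and compound 4 at 1500 nM differ at the same carbon, so both the bromo group and the larger group of compound 3 stand with higher numbers than hydrogen does in this short series. Nothing available here explains the size of this step.

From the compounds shown here alone, whether a methyl group, a fluoro group or an amine at this carbon would stay near compound 4 or move towards compound 1 remains open. Equally open, going by these compounds, is whether a carboxylic acid or a longer chain in place of the cyanomethyl group would shift the number of compound 4.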